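The compounds below may be only part of what the source reports. "The series", "measured", "known", "first", "only" and "open" are said of these compounds alone.

Measured so far in an assay on isolated protein for inhibition of polyamine deacetylase HDAC10 (Homo sapiens); on this read-out higher numbers stand for weaker inhibition and lower numbers for stronger inhibition:
- compound 1 `Cc1ccc(C(=O)c2ccc3c(ccn3Cc3ccc(C(=O)NO)cc3)c2)cc1`: > 100000 nM
- compound 2 `COc1ccc(C(=O)c2ccc3c(ccn3S(=O)(=O)c3cccc(/C=C/C(=O)NO)c3)c2)cc1OC`: 8240 nM
- compound 3 `COc1cc(C(=O)c2ccc3c(ccn3Cc3ccc(/C=C/C(=O)NO)cc3)c2)cc(OC)c1OC`: "not determined" (no result reported)

Going by the values given here, compound 2 holds the only number in this assay; compound 1 sits at the limit of > 100000 nM in this assay, at which 1 of the 3 values shown sits, which is a limit of the assay and not a number, and compound 3 has no reported result. Among the compounds with values here, there is thus no measured step to draw on, and no comparison between compound 2 and the others can be put in figures.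

Compound 4 `COc1cc(C(=O)c2ccc3c(ccn3S(=O)(=O)c3cccc(/C=C/C(=O)NO)c3)c2)cc(OC)c1OC` is the next entry, not yet measured. It differs from compound 2 in one place: methoxy in place of hydrogen on an aromatic carbon. Read one bond further out, the change is 3,4-dimethoxyphenyl to 3,4,5-trimethoxyphenyl.

Within the data shown here, with no measured step in this assay, the expectation for the step from compound 2 to compound 4 is a change no larger than the usual scatter, in either direction: a 1.0-fold lower number from compound 2 to compound 4 (0.01 log units; within the scatter). Starting from compound 2 at 8240 nM, compound 4 is estimated at 8000 nM, with a range from 3000 nM to 25000 nM.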

Compound 4, half-maximal inhibitory concentration: > 100000 nM
Compound 4: no number, only a limit (the forecaster's own chance of this, stated with the estimate: 15%); middle value at least 12-fold (1.09 log units) away from the limit.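

At the ring carbon ortho to a methoxy group and meta to a large group, the change from 3,4-dimethoxyphenyl to 3,4,5-trimethoxyphenyl is not neutral in this assay: methoxy in place of hydrogen gives an at least 12-fold higher number from compound 2 to compound 4 (1.08 log units; beyond the scatter). On these data alone, compound 4 gives > 100000 nM, which is a limit of the assay and not a number, so the full size of this step stays unknown. With this result, compound 2 remains the only compound with a number, and a second compound sits at the limit: the limit of > 100000 nM in this assay, at which 2 of the 4 values shown sit.

As far as these compounds go, whether this loss is specific to methoxy stays open, since a smaller group at the same carbon, such as hydroxy or fluorine, or an amine, could separate the effect of the group from that of filling the position. Also open, from the compounds shown here alone, is whether the same change has a similar effect when the rest of the structure differs.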